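Allyl for phenyl on the carbamate of a trifluoromethyl ketone

A few compounds are considered here, and "the series" means these few. Any claim that something is new, unique, unknown or untested is made for them only; others in the source may bear on it.

Measured compounds:
compound 1 `O=C(c1ccccc1)C(O)C(F)(F)F` in a functional assay (Homo sapiens) for cytotoxicity (a lower number here means that less compound is tolerated, a higher number that more compound is tolerated), gives 36000 nM
compound 2 `CCCCCCC(=O)C(O)C(F)(F)F` in this assay gives 90000 nM
compound 3 `O=C(Oc1ccccc1)N1C=C(C(=O)C(F)(F)F)CC1` in this assay gives 230000 nM

Of the three numbers in this assay, compound 3 holds the highest; its gap to compound 2, the nearest, lies beyond the scatter, and the gap to compound 1 is wider still. All three share a trifluoromethyl ketone, but only compound 3 carries it on a ring bearing a carbamate.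

Compound 4 `C=CCOC(=O)N1C=C(C(=O)C(F)(F)F)CC1` has not yet been measured. It differs from compound 3 in one place: allyl in place of phenyl on an oxygen next to a carbonyl group. Among the compounds with values here, no other pair of measured compounds shows this exchange, so no measured step can be drawn on. Since the change is confined to the group on the carbamate oxygen and the rest of compound 3 is kept, the step in this assay is expected to stay within the scatter, with no clear direction: no change at the digits printed from compound 3 to compound 4 (within the scatter) is the expected move. Compound 4 is therefore estimated to give 230000 nM in this assay, within the range 90000 nM to 600000 nM.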

Compound 4, half-maximal cytotoxic concentration: 110000 nM
For compound 4 the middle estimate is 2.1-fold (0.32 log units) above the measured one, and the stated range covers the measured number.
By their numbers in this assay, from the lowest: compound 1; then compounds 2 and 4 (each within the scatter of the next); then compound 3.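

In this assay, the group on the carbamate oxygen proves able to move the number: allyl in place of phenyl gives a 2.1-fold lower number from compound 3 to compound 4 (0.32 log units; beyond the scatter), a modest step that lies beyond the scatter. Within the data shown here, this is the first reading at this position, as the earlier compounds offered no pair differing in one place, and its direction is toward less compound being tolerated when the aromatic ring leaves. Nothing at hand accounts for this step.

A single exchange cannot separate the loss of the ring from the arrival of the double bond, and a propyl or benzyl group on the same oxygen would be needed to tell them apart. Also open, from the compounds shown here alone, is whether the oxygen itself matters, for which an amine nitrogen in its place would be the test.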